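Swapping the benzyl halogen pattern on a sulfur-linked chain

The source may report more compounds than this note shows. Statements on the series, on what has been measured and on what is new or still open speak of the compounds shown alone.

For the measured compounds named here, compound 1 `Cc1ccsc1/C=C(/SCc1ccc(F)cc1)C(=O)c1ccc(Cl)cc1` is one of two compounds measured in a functional assay on DU-145 cells (Homo sapiens) for inhibition, read by trypan blue exclusion, with a stated time of 96 h (on this read-out lower numbers stand for stronger inhibition of growth and higher numbers for weaker inhibition of growth), where compound 1 gives 50000 nM. Going by the values given here, its only measured neighbour is compound 2 `O=C(/C(=C\c1ccc(O)cc1)SCc1ccc(F)cc1)c1ccc(Cl)cc1`, which in this assay gives 25000 nM; the step of a 2.0-fold lower number from compound 1 to compound 2 (0.30 log units; within the scatter) swaps the group on a double-bonded chain carbon and lies within the scatter, so the two numbers cannot be told apart.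

Compound 3 `Cc1ccsc1/C=C(/SCc1ccc(Cl)cc1Cl)C(=O)c1ccc(Cl)cc1` has not yet been measured. Its difference from compound 1 is 2,4-dichlorophenyl in place of 4-fluorophenyl on a saturated chain carbon bound to a sulfur. Among the compounds with values here, the only measured step, from compound 1 to compound 2, touches a different part of the shared core, so no measured step bears directly on this change. Within the data shown here, the one step available was within the scatter, and with nothing pointing either way the expectation for this assay is no step beyond the scatter, expressed as no change at the digits printed from compound 1 to compound 3 (within the scatter). Compound 3 is therefore expected to give about 50000 nM, with a range from 15000 nM to 160000 nM in this assay.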

Compound 3, concentration for 50% growth inhibition: 10000 nM
Estimate against measurement, compound 3: 5.0-fold (0.70 log units) above, outside the stated range (below it).
By their numbers in this assay, from the lowest: compound 3; then compounds 2 and 1 (each within the scatter of the next).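

For the compounds shown here, the sulfur-linked benzyl group is the first place in this set where a single change moves the number beyond the scatter. In this assay, exchanging the 4-fluorobenzyl group for the 2,4-dichlorobenzyl group gives a 5.0-fold lower number from compound 1 to compound 3 (0.70 log units; beyond the scatter) and so points modestly towards stronger inhibition of growth, whereas the earlier change on the double-bonded chain carbon gave only a 2.0-fold lower number from compound 1 to compound 2 (0.30 log units; within the scatter) and stayed within the scatter. This one step removes a fluorine and adds two chlorines together, so it cannot separate the kind of halogen from the number of halogens, and no supporting measurement bears on why the number fell.

The compounds shown leave open whether an unsubstituted phenyl, a trifluoromethyl group or an amine on this ring would shift the number further, and whether a single chlorine would be enough to produce a step of this size. They also leave open whether the 2,4-dichlorobenzyl group would give a similar step when paired with the 4-hydroxyphenyl group of compound 2.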